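From (isopropylcarbonyl)amino to amino: notes toward compound 3

This account rests on a few compounds, and the source may have more. Where it says the series, first, only, none or still open, it means among the compounds named here.

Of the compounds shown here, two carry numbers so far. Compound 1 `O=C1Nc2ccccc2/C1=C\C(=O)c1cc(F)cc(F)c1` gives 17600 nM in a functional assay on SGC-7901 cells (Homo sapiens) for inhibition, read by MTT assay, with a stated time of 72 h; on this read-out lower numbers stand for stronger inhibition and higher numbers for weaker inhibition. Compound 2 `CC(C)C(=O)Nc1cccc(C(=O)/C=C2/C(=O)Nc3ccccc32)c1` gives 8600 nM in this assay, the lower of the two numbers; the gap to compound 1 lies beyond the usual scatter, so compound 2 stands as the stronger inhibitor of the pair. Among the compounds with values here, the two measured compounds differ in more than one place, so no single step has yet been measured, and nothing is known about how the group on the aromatic nitrogen affects the read-out.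

Compound 3 `Nc1cccc(C(=O)/C=C2/C(=O)Nc3ccccc32)c1` is still to be measured. It differs from compound 2 in one place: hydrogen in place of isopropylcarbonyl on a nitrogen on an aromatic ring. The change strips the amide down to a free amino group on the same ring position. Within the data shown here, with no measured step touching this nitrogen, the direction of the change is open; the working expectation is a step of no more than the usual scatter, if anything slightly toward weaker inhibition. For compound 3 in this assay the estimate is 11000 nM, within a range of 3500 nM to 35000 nM. The expected step is a 1.3-fold higher number from compound 2 to compound 3 (0.11 log units; within the scatter).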

Compound 3, half-maximal inhibitory concentration: 14400 nM
Compound 3: the middle estimate sits 1.3-fold (0.12 log units) below what was measured, and the stated range covers the measured number.
By their numbers in this assay, from the lowest: compounds 2, 3 and 1 (each within the scatter of the next, the first and the last beyond it).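

Within the data shown here, this is the first measured step at the nitrogen on the aromatic ring. In this assay hydrogen in place of isopropylcarbonyl gives a 1.7-fold higher number from compound 2 to compound 3 (0.22 log units; within the scatter), so taking away all 5 heavy atoms of that group, its carbonyl included, leaves a result that cannot be told apart from that of the amide. At this level of inhibition, the isopropylcarbonyl group is thus not shown to be required, and the free amino group of compound 3 serves as a measured reference point for this nitrogen; no available measurement bears on why the two compounds read alike.

The compounds shown leave open whether any other group on this nitrogen would move the number beyond the scatter, for example a smaller acetyl group, a longer acyl chain, a methylsulfonyl group or a simple methyl group on the amine. They also leave open whether a carboxylic acid carried on a chain from this nitrogen would read differently, and whether hydrogen in place of isopropylcarbonyl would give a similar result on other cell lines.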